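The source may hold more compounds than are shown below. What is called first, only, known or untested is meant among the compounds shown, and "the series" means these compounds.

Measured so far:
Compound 1, `O=C(Nc1ccccc1)c1cc(Br)ccc1O`, in an assay on isolated protein for inhibition of thiosulfate sulfurtransferase (Homo sapiens), with a stated time of 60 min, in the absence of a further agent (a higher number here means a weaker inhibitor, a lower number a stronger inhibitor), gives > 100000 nM, which is a limit of the assay and not a number.
Compound 2, `O=C(Nc1ccccc1)c1cc(Br)cc(Br)c1O`, in this assay gives > 100000 nM, also a limit.
Compound 3, `O=C(Nc1cccc(Cl)c1)c1cc(Br)ccc1O`, in this assay gives > 100000 nM, likewise a limit.

All three values sit at the limit of > 100000 nM in this assay, at which 3 of the 3 values shown sit, so compound 1 stands at a limit in this assay with no measured number of its own, and the same holds for compound 2 and compound 3. The step that the two limits leave unreadable from compound 1 to compound 2 and the step that the two limits leave unreadable from compound 1 to compound 3 therefore cannot be read in size or direction, as two limits cannot be compared.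

Compound 4, `O=C(Nc1ccccc1)c1cccc(Br)c1`, differs from compound 1 by hydrogen in place of hydroxy on an aromatic carbon. Within the data shown here, no measured step concerns removal of the hydroxy group; the two known steps involve halogens entering elsewhere and are unreadable in any case. Among the measured compounds shown here, with compound 1 at the limit of > 100000 nM in this assay, at which 3 of the 3 values shown sit, no direction for the step to compound 4 can be read, and the expectation is simply that compound 4 also fails to reach a measurable value in this assay. Compound 4 is therefore estimated at 200000 nM, within 40000 nM to 1000000 nM. The step that the limit leaves unreadable from compound 1 to compound 4 implied by this estimate is expected to remain unreadable against a limit.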

Compound 4, half-maximal inhibitory concentration: > 100000 nM
Compound 4: only a limit was reported; the forecaster's own chance of this, stated with the estimate: 90%; the middle value lies beyond the limit too.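

Compound 4 in this assay gives > 100000 nM, which is a limit of the assay and not a number. Compound 1 also stands at a limit, so the step from compound 1 to compound 4 cannot be read: the limit of > 100000 nM in this assay, at which 4 of the 4 values shown sit. The compounds shown leave open whether any change to the shared core gives a measurable inhibition.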